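Half-life after swapping phenyl for dimethylamino on the sulfonyl sulfur

The compounds below may be only part of what the source reports. "The series", "measured", "known", "first", "only" and "open" are said of these compounds alone.

Measured in an ADME assay on the whole organism (Rattus norvegicus, strain Harlan-Han Wistar) for metabolic stability; a higher number here means that the compound lasts longer, a lower number that the compound disappears faster:
compound 1 `Cc1ccc2[nH]c(C(=O)N[C@H]3CN(S(=O)(=O)c4ccnc(C)c4)C[C@@H]3C(=O)NCCN(C)C)cc2c1` gives 0.8 h
compound 2 `Cc1ccc2[nH]c(C(=O)N[C@H]3CN(S(=O)(=O)c4cn(C)nc4C)C[C@@H]3C(=O)NCCN(C)C)cc2c1` gives 2.1 h
compound 3 `Cc1ccc2[nH]c(C(=O)N[C@H]3CCN(S(=O)(=O)c4ccccc4)C[C@@H]3C(=O)NCCN(C)C)cc2c1` gives 1.8 h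

Compound 3 at 1.8 h lies within the scatter of compound 2 and clearly higher than compound 1. Compound 4 `Cc1ccc2[nH]c(C(=O)N[C@H]3CCN(S(=O)(=O)N(C)C)C[C@@H]3C(=O)NCCN(C)C)cc2c1` changes it as follows: dimethylamino in place of phenyl on a sulfonyl sulfur. Within the data shown here, the only measured step at this sulfur is a 2.6-fold higher number from compound 1 to compound 2 (0.42 log units; beyond the scatter), which exchanges one ring for another on a different core, and it gives no direction for a group without a ring. No step beyond the scatter is therefore expected in this assay. The expected step is no change at the digits printed from compound 3 to compound 4 (within the scatter). For compound 4 the estimated value is 1.8 h, with an expected range of 0.9 h to 3.5 h.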

Compound 4, half-life: 1.8 h
Estimate against measurement, compound 4: no gap at the digits printed; measured number inside the range.
By their numbers in this assay, from the lowest: compound 1; then compounds 3, 4 and 2 (each within the scatter of the next).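

Replacing the ring on the sulfonyl sulfur with a group that has none gives no change at the digits printed from compound 3 to compound 4 (within the scatter) in this assay. On this core, then, the phenyl ring is not needed to keep the half-life in this range, and dimethylamino, with fewer heavy atoms, reads the same. Nothing measured here bears on the reason for this result. On these data alone, it remains open whether a morpholine or a plain methyl on the sulfonyl sulfur would read alike, and whether dimethylamino would behave the same way on the core of compound 1.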